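Amide aryl variation on a shared sulfonamide oxime core

The source may report more compounds than this note shows. Statements on the series, on what has been measured and on what is new or still open speak of the compounds shown alone.

Compound 1 `CCOC1=C(/C(C)=N/OCC(=O)Nc2ccc(OC)cc2)N(C)S(=O)(=O)c2ccccc21`: in a functional assay on THP-1 cells (Homo sapiens) for inhibition, read by ELISA, with stated times of 2 h and 48 h (a higher number here means a weaker inhibitor, a lower number a stronger inhibitor), compound 1 gives > 20000 nM, a limit of the assay.
Compound 2 `CCOC1=C(/C(C)=N/OCC(=O)Nc2ccc(F)c(Cl)c2)N(C)S(=O)(=O)c2ccccc21`: in this assay compound 2 gives > 20000 nM, likewise a limit.
Compound 3 `COc1ccc(NC(=O)CO/N=C(\C)C2=C(O)c3ccccc3S(=O)(=O)N2C)cc1`: in this assay compound 3 gives > 20000 nM, again a limit.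

Compound 3 thus stands at the limit of > 20000 nM in this assay, at which 3 of the 3 values shown sit, with no number of its own. The steps a step that the two limits leave unreadable from compound 1 to compound 2 and a step that the two limits leave unreadable from compound 1 to compound 3 are both unreadable, since each end is a limit. Compound 4 `C/C(=N\OCC(=O)Nc1c(F)cccc1F)C1=C(O)c2ccccc2S(=O)(=O)N1C` differs from compound 3 by 2,6-difluorophenyl in place of 4-methoxyphenyl on an amide-type nitrogen. Going by the values given here, the only measured step on the amide-type nitrogen, a step that the two limits leave unreadable from compound 1 to compound 2, gives no size, so no shift beyond the scatter can be read from it. Compound 4 is therefore expected to return a limit as well, the expected step being a number no higher from compound 3 to compound 4 (the limit leaves the size open). The estimate for compound 4 in this assay is 20000 nM, within a range from 5000 nM to 80000 nM.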

Compound 4, half-maximal inhibitory concentration: > 20000 nM
Compound 4: no number, only a limit (the forecaster's own chance of this, stated with the estimate: 80%); the middle value sits exactly at the limit.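

Going by these compounds alone, with compound 3 and compound 4 both at a limit in this assay, no step between them can be read. The compounds shown leave open whether the aryl group on the amide-type nitrogen affects inhibition at all.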